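Swapping a furan for a chlorophenyl on the shared core

The source may hold more compounds than are shown below. What is called first, only, known or untested is meant among the compounds shown, and "the series" means these compounds.

Compound 2 `Clc1ccc(-c2cc(-c3ccco3)nc(-c3cccs3)c2)o1` gives 18800 nM in a functional assay on HeLa cells (Homo sapiens) for cytotoxicity, in the presence of a further agent that is not named here (a higher number here means a weaker inhibitor, a lower number a stronger inhibitor), the highest of the two numbers measured. Compound 1 `Clc1ccc(-c2cc(-c3ccsc3)nc(-c3ccccc3Cl)c2)o1` gives 8070 nM in this assay, a gap beyond the usual scatter. Compound 3 `Clc1ccc(-c2cc(-c3cccs3)nc(-c3ccccc3Cl)c2)o1` is not yet measured; it differs from compound 2 by 2-chlorophenyl in place of furan-2-yl on an aromatic carbon. Compound 3 carries the same 2-chlorophenyl next to the ring nitrogen as compound 1, so compound 3 is expected to land near compound 1 at 8070 nM. The step from compound 2 is expected to be modest, toward a lower number, as a 2.1-fold lower number from compound 2 to compound 3 (0.32 log units; beyond the scatter). The estimate for compound 3 is 9000 nM, between 4000 nM and 20000 nM.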

Compound 3, half-maximal inhibitory concentration: 18500 nM
Compound 3: the middle estimate sits 2.1-fold (0.31 log units) below what was measured; low and high end bracket the measured number.
By their numbers in this assay, from the lowest: compound 1; then compounds 3 and 2 (each within the scatter of the next).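

In this assay, placing 2-chlorophenyl instead of furan-2-yl on this carbon next to the ring nitrogen gives a 1.0-fold lower number from compound 2 to compound 3 (0.01 log units; within the scatter), so this pair does not tell the two groups apart. Sharing 2-chlorophenyl also does not bring compound 3 level with compound 1: thiophen-2-yl in place of thiophen-3-yl gives a 2.3-fold higher number from compound 1 to compound 3 (0.36 log units; beyond the scatter), so the thiophene's point of attachment counts in this pair. Nothing available explains either result. As far as these compounds go, whether an amine or a carboxylic acid on this carbon would match these two groups remains open. So does whether the thiophene step holds with furan-2-yl in place of 2-chlorophenyl.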